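Two methoxy groups on the amide ring, tested for cell toxicity

The source may report more compounds than this note shows. Statements on the series, on what has been measured and on what is new or still open speak of the compounds shown alone.

Compound 1 `COc1ccc(NC(=O)c2cccc(/C=C3\CC(=O)N(c4ccccc4)C3=O)c2)cc1` was examined in an ADME assay on NCM460 cells (Homo sapiens) for cytotoxicity, read by MTT assay, with a stated time of 72 h; on this read-out lower numbers stand for stronger inhibition and higher numbers for weaker inhibition. In this assay compound 1 gives > 100000 nM, which is a limit of the assay and not a number. A related compound, compound 2 `CCCCCN1C(=O)C/C(=C\c2cccc(C(=O)Nc3cccc(F)c3)c2)C1=O`, was run in this assay and compound 2 gives > 100000 nM, again a limit. Compound 3 `COc1ccc(NC(=O)c2cccc(/C=C3\CC(=O)N(c4ccc(C)cc4)C3=O)c2)cc1` was also run, and in this assay compound 3 gives > 100000 nM, once more a limit. Among the compounds with values here, the only step measured between two compounds, a step that the two limits leave unreadable from compound 1 to compound 3, cannot be read because of the limit of > 100000 nM in this assay, at which 3 of the 3 values shown sit. Compound 4 `COc1ccc(OC)c(NC(=O)c2cccc(/C=C3\CC(=O)N(c4ccccc4)C3=O)c2)c1` has not yet been measured. It differs from compound 1 by 2,5-dimethoxyphenyl in place of 4-methoxyphenyl on an amide-type nitrogen. Within the data shown here, no measured step touches this change, and no measured step in this assay gives a readable size at all, so the expectation rests on the pattern that every value shown sits at the limit. Compound 4 is therefore expected to give about 100000 nM in this assay. For compound 4 the estimated range runs from 30000 nM to 300000 nM. The expected step is a number no higher from compound 1 to compound 4 (the limit leaves the size open), which is none beyond the scatter.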

Compound 4, half-maximal inhibitory concentration: > 100000 nM
Compound 4 ended at the assay's limit; the forecaster's own chance of this, stated with the estimate: 80%; the middle value sits exactly at the limit.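

No step can be read from compound 1 to compound 4 in this assay because both results are limits of the assay and not numbers: the limit of > 100000 nM in this assay, at which 4 of the 4 values shown sit. The compounds shown leave open what concentration, if any, would harm these cells, and whether 2,5-dimethoxyphenyl in place of 4-methoxyphenyl changes it.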